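Adding a Methyl Group to the Pyridine of Compound 3

A few compounds are considered here, and "the series" means these few. Any claim that something is new, unique, unknown or untested is made for them only; others in the source may bear on it.

Measured so far:
compound 1 `N/C(=N\NC(=S)N1CCOCC1)c1ccccn1` gives 4800 nM in a functional assay on A-431 cells (Homo sapiens) for cytotoxicity, read by MTT assay, with a stated time of 72 h; on this read-out higher numbers stand for weaker inhibition and lower numbers for stronger inhibition
compound 2 `Cc1ccnc(/C(N)=N/NC(=S)N2CCSCC2)c1` gives 7200 nM
compound 3 `N/C(=N\NC(=S)N1CCCC1)c1ccccn1` gives 1700 nM

Compound 3 has the lowest number of the three. Among the measured compounds shown here, the only single-change comparison available is a 2.8-fold lower number from compound 1 to compound 3 (0.45 log units; beyond the scatter), which concerns the ring attached to the thiocarbonyl carbon, not the aromatic ring. Compound 4 `Cc1ccnc(/C(N)=N/NC(=S)N2CCCC2)c1` differs from compound 3 by methyl in place of hydrogen on an aromatic carbon. For the measured compounds named here, no measured pair isolates this change: compound 2 carries the same methyl but also a different ring on the thiocarbonyl, so its value of 7200 nM cannot be attributed to the methyl alone. Going by the values given here, with no direct precedent, a step within the usual scatter is expected for compound 4, written as a 1.3-fold higher number from compound 3 to compound 4 (0.11 log units; within the scatter). The estimate for compound 4 is 2200 nM, with a range from 900 nM to 5500 nM.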

Compound 4, half-maximal inhibitory concentration: 900 nM
The estimate for compound 4 lay 2.4-fold (0.39 log units) above the measured number; the measured number falls inside the stated range.
By their numbers in this assay, from the lowest: compounds 4 and 3 (each within the scatter of the next); then compounds 1 and 2 (each within the scatter of the next).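

Placing methyl on this aromatic carbon, opposite the ring nitrogen, gives a 1.9-fold lower number from compound 3 to compound 4 (0.28 log units; within the scatter), so this first direct test in this assay shows no change beyond the scatter. With that methyl present in both compounds, pyrrolidin-1-yl in place of thiomorpholin-4-yl gives an 8.0-fold lower number from compound 2 to compound 4 (0.90 log units; beyond the scatter), showing that the ring on the thiocarbonyl carbon still counts once the methyl is there. Nothing available explains either step.

Going by these compounds, it remains open how an ethyl, a methoxy or an amine would behave on this same carbon. On these data alone, whether methyl would give a similar step alongside morpholin-4-yl is also open.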